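Amide cap change on the ether-linked analogue

The compounds below may be only part of what the source reports. "The series", "measured", "known", "first", "only" and "open" are said of these compounds alone.

Measured compounds:
compound 1, `COc1ccc(-c2cc(NC(=O)CCC(=O)NCC(=O)NC3CCCCC3)nc(-c3ccc(OC)cc3)n2)cc1`, 74200 nM
compound 2, `COc1ccc(-c2cc(NC(=O)COCC(=O)NCC(=O)NC(C)(C)C)nc(-c3ccc(OC)cc3)n2)cc1`, 19700 nM

In an assay on HeLa cells for displacement of a labelled ligand from adenosine receptor A3 (Homo sapiens), read by fluorescence polarization, with a stated time of 30 min (a higher number here means a weaker inhibitor, a lower number a stronger inhibitor), compound 2 gives 19700 nM, the lower of the two numbers measured; compound 1 gives 74200 nM, and that gap lies beyond the scatter. Compound 3, `COc1ccc(-c2cc(NC(=O)COCC(=O)NCC(=O)NC3CCCCC3)nc(-c3ccc(OC)cc3)n2)cc1`, keeps the chain of compound 2 and differs from it only in one place: cyclohexyl in place of tert-butyl on an amide-type nitrogen. Compound 1 also carries cyclohexyl on that nitrogen, but it differs from compound 3 in the chain as well, so its value cannot be read as a step for this change. For the measured compounds named here, with no measured step for this change, the expected step of a 1.3-fold higher number from compound 2 to compound 3 (0.10 log units; within the scatter) is small, not clearly beyond the scatter, in either direction. Compound 3 is estimated at 25000 nM, with a range of 8000 nM to 80000 nM.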

Compound 3, inhibition constant: 21400 nM
Compound 3: the middle estimate sits 1.2-fold (0.07 log units) above what was measured; measured number inside the range.
By their numbers in this assay, from the lowest: compounds 2 and 3 (each within the scatter of the next); then compound 1.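

this assay shows a 1.1-fold higher number from compound 2 to compound 3 (0.04 log units; within the scatter) on the ether-linked chain, so cyclohexyl and tert-butyl on this amide-type nitrogen read alike, with or without a ring. With cyclohexyl on that nitrogen in both, compound 3 gives 21400 nM and compound 1 gives 74200 nM on their different chains, so the gap between those two values goes with the chain, not the cap. No measured evidence accounts for the likeness of the two caps.

Open, as far as these compounds go, is whether a phenyl group, an amine or a carboxylic acid on this nitrogen would depart from these values. From the compounds shown here alone, a longer chain also remains open.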